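The source may report more compounds than this note shows. Statements on the series, on what has been measured and on what is new or still open speak of the compounds shown alone.

Two compounds that share an amide-linked oxalate ester on a seven-membered aromatic ring have been tested in a functional assay on the whole organism (strain Sprague-Dawley CD) for inhibition, with Rattus norvegicus as the target, read by paw edema, at a dose of 30 mg/kg by the intraperitoneal route; on this read-out lower numbers stand for a weaker effect and higher numbers for a stronger effect at the one dose given. Compound 1 `COC(=O)C(=O)Nc1ccc(OC)c(=O)cc1` gives 36% in this assay. Compound 2 `CCOC(=O)C(=O)Nc1ccccc(C)c1=O` gives 60% in this assay, the higher of the two numbers; its nearest neighbour is compound 1, whose value lies lower by a gap beyond the usual scatter. Going by the values given here, the two compounds differ from one another in more than one place, so no single step between them can be read off.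

Compound 3 `CCOC(=O)C(=O)Nc1ccccc(NC)c1=O` has not yet been measured. It differs from compound 2 by one change: methylamino in place of methyl on an aromatic carbon. Among the compounds with values here, no measured pair in this set isolates such a change, so there is no step on which to rest a direction. The step from compound 2 to compound 3 is therefore expected to be small, a number 5 percentage points lower from compound 2 to compound 3 (within the scatter), and may well fall within the scatter in either direction. Compound 3 is estimated to give 55% in this assay, with a range from 35% to 75% reflecting that uncertainty.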

Compound 3, a percentage reported as inhibition, in the whole organism at one dose (the size of the read-out at that dose, not a potency): 83%
For compound 3 the middle estimate is 28 percentage points below the measured one, outside the stated range (above it).
By their numbers in this assay, from the lowest: compound 1; then compound 2; then compound 3.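

The place on an aromatic carbon, two ring bonds from the ring atom that bears a group of 8 heavy atoms, now proves not to be indifferent to what it carries: with methylamino in place of methyl, this assay shows a number 23 percentage points higher from compound 2 to compound 3 (beyond the scatter). Going by these compounds alone, this is the first change in the set that can be read at a single place, and it adds one nitrogen, one hydrogen-bond donor and one hydrogen-bond acceptor to the group at that carbon, so these counts are what separates the pair. No measurement offered here accounts for the upward direction of the step.

The compounds shown leave open whether the gain follows the nitrogen alone or the amine hydrogen as well, which a plain amine, a dimethylamino group or a methoxy group at the same carbon would help to separate. They also leave open how far a longer chain on that nitrogen would carry the effect, and whether the step would hold with the methyl ester in place of the ethyl ester.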